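The source may report more compounds than this note shows. Statements on the series, on what has been measured and on what is new or still open speak of the compounds shown alone.

Of the compounds shown here, two carrying the same core have been measured. Compound 1 `O[C@@H]1[C@H](O)CS[C@H]1Cn1cnc2c(NCc3cccc(Cl)c3)ncnc21` gives 3.3% in an assay on CHO cells for displacement of a labelled ligand from adenosine receptor A1 (Homo sapiens), with a stated time of 60 min, tested at 10 uM; on this read-out higher numbers stand for more inhibition at the one concentration tested (going by the name of the read-out) and lower numbers for less inhibition. Compound 2 `O[C@@H]1[C@H](O)CS[C@H]1Cn1cnc2c(NCc3cccc(Cl)c3)nc(Cl)nc21`, which carries a chloro in place of hydrogen on an aromatic carbon of that core, gives 3.2% in this assay. Going by the values given here, the one measured step, a number 0.1 percentage points lower from compound 1 to compound 2 (within the scatter), lies within the scatter, so compound 2 and compound 1 stand together at a low level of inhibition, with no difference between them that the measurement can resolve.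

Compound 3 `O[C@@H]1[C@H](O)CS[C@H]1Cn1cnc2c(NCc3cccc(F)c3)nc(Cl)nc21` differs from compound 2 at a different place: fluoro in place of chloro on an aromatic carbon. Among the compounds with values here, no measured pair shows this swap of one halogen for another on the six-membered ring of carbon only, so the data offer no direct guide to its size; the one step that is known, from compound 1 to compound 2, touched the core and not this ring, and was within the scatter.

With both measured compounds at low inhibition and no sign that a single halogen swap moves the read-out, the expectation for compound 3 is a step of a number 0.2 percentage points lower from compound 2 to compound 3 (within the scatter), which is no change beyond the scatter. Compound 3 is therefore estimated at 3% in this assay, with a range from -7% to 13%.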

Compound 3, a percentage reported as inhibition, at one concentration (the size of the read-out at that concentration, not a potency): 7.9%
For compound 3 the middle estimate is 4.9 percentage points below the measured one; measured number inside the range.
By their numbers in this assay, from the lowest: compounds 2, 1 and 3 (each within the scatter of the next).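

In this assay, going by these compounds alone, replacing the 3-chlorobenzyl group with the 3-fluorobenzyl group gives a number 4.7 percentage points higher from compound 2 to compound 3 (within the scatter), and this is the first measured change on the six-membered aromatic ring of carbon only, as the earlier step touched the core. At this place on the ring, meta to a large group, chloro and fluoro therefore cannot be told apart by this measurement, so the exchange of one halogen for the other shows no resolved effect on inhibition at the one concentration tested. The data shown contain no separate evidence that could add anything further about this step.

Chloro and fluoro are both single heavy atoms with no hydrogen-bond donors or acceptors, so this pair says little about how a quite different group would behave at the same place, such as an amine, a carboxylic acid or a longer chain like propyl. Also open is whether any replacement on this ring could lift inhibition beyond the scatter, since the compounds shown sample only these two halogens there.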